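The compounds below may be only part of what the source reports. "The series", "measured", "known", "first", "only" and "open" are said of these compounds alone.

Compound 3 `CCOc1nc(N)c2nc(O)n(Cc3ccccc3)c2n1` is one of the two compounds with the lowest numbers seen in a functional assay (spleen, spleen) for activation, with Mus musculus as the target (a lower number here means that less compound is needed, a higher number that more compound is needed for the effect), where compound 3 gives 0.1 uM. Compound 2 `CCCCCNc1nc(N)c2nc(O)n(Cc3ccccc3)c2n1` gives 0.1 uM, and the two are level, as no change at the digits printed from compound 2 to compound 3 (within the scatter) shows. Compound 1 `Cc1nc(N)c2nc(O)n(Cc3ccccc3)c2n1` gives 1 uM, so it needs more compound, with a 10-fold lower number from compound 1 to compound 3 (1.00 log units; beyond the scatter) and a 10-fold lower number from compound 1 to compound 2 (1.00 log units; beyond the scatter).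

Compound 4 `Nc1nc(N)c2nc(O)n(Cc3ccccc3)c2n1` differs from compound 3 in one place: amino in place of ethoxy on an aromatic carbon.

Within the data shown here, no measured step swaps an ethoxy for an amino, so the bearing of the three steps is indirect. Both larger groups, pentylamino and ethoxy, lowered the number from the methyl of compound 1 by the same modest amount. The amino that enters resembles neither of them, so some of that gain may be lost, though the scale of the three steps suggests nothing dramatic. The expected step is a 5.0-fold higher number from compound 3 to compound 4 (0.70 log units; beyond the scatter), toward a higher number. Compound 4 is therefore estimated at 0.5 uM, within a range from 0.1 uM to 3 uM.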

Compound 4, minimum effective concentration: 10 uM
Compound 4: the middle estimate sits 20-fold (1.30 log units) below what was measured, and the stated range ends below it.
By their numbers in this assay, from the lowest: compounds 2 and 3 (each within the scatter of the next); then compound 1; then compound 4.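

In this assay the amino on this carbon between two ring nitrogen atoms gives a 100-fold higher number from compound 3 to compound 4 (2.00 log units; beyond the scatter) and a 100-fold higher number from compound 2 to compound 4 (2.00 log units; beyond the scatter) and also a 10-fold higher number from compound 1 to compound 4 (1.00 log units; beyond the scatter) as it falls behind even the methyl. The step from compound 2 only replaces the pentyl on the nitrogen with hydrogen, so in these compounds a nitrogen on this carbon does not by itself give a low number, and the pentyl makes a large difference. Nothing available explains why the amino differs so sharply from the other groups.

Still open, as far as these compounds go, is whether a shorter chain on that nitrogen, such as methylamino or propylamino, already brings the number back down. From the compounds shown here alone, it is also open whether methoxy or the longer butoxy matches ethoxy on this carbon.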